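The source may hold more compounds than are shown below. What is called first, only, known or untested is meant among the compounds shown, and "the series" means these compounds.

Compound 1 is `O=C(CSc1nnc(NC(=O)c2c(Cl)cccc2Cl)s1)Nc1ccc(Br)cn1`; in a functional assay on NCI-H460 cells (Homo sapiens) for antiproliferative activity, read by MTT assay, with a stated time of 48 h (a higher number here means a weaker inhibitor, a lower number a stronger inhibitor), compound 1 gives 16800 nM.
Compound 2 is `COc1ccccc1C(=O)Nc1nnc(SCC(=O)Nc2ccc(Br)cn2)s1`; in this assay compound 2 gives > 80000 nM, which is a limit of the assay, not a number (the limit of > 80000 nM in this assay, at which 1 of the 3 values shown sits).
Compound 3 is `O=C(CSc1nnc(NC(=O)C(Cl)Cl)s1)Nc1ccc(Br)cn1`; in this assay compound 3 gives 5300 nM.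

Compound 3 holds the lowest number shown: the step of a 3.2-fold lower number from compound 1 to compound 3 (0.50 log units; beyond the scatter) is modest, and the step of an at least 15-fold lower number from compound 2 to compound 3 (1.17 log units; beyond the scatter) is large. Compound 4 is `O=C(CSc1nnc(NC(=O)CCCl)s1)Nc1ccc(Br)cn1`, differing from compound 3 by 2-chloroethyl in place of dichloromethyl on a carbonyl carbon. Among the measured compounds shown here, both measured steps trade an aromatic ring for the dichloromethyl group; no measured step exchanges one small chain for another, so they bear only loosely on this change. In this assay compound 4 is therefore expected to stay near compound 3, with a step of a 1.7-fold higher number from compound 3 to compound 4 (0.23 log units; within the scatter) estimated to lie within or just beyond the scatter. The estimate for compound 4 is 9000 nM, ranging from 3000 nM to 30000 nM.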

Compound 4, half-maximal inhibitory concentration: 560 nM
Compound 4: the middle estimate sits 16-fold (1.21 log units) above what was measured; measured number below the stated range.
By their numbers in this assay, from the lowest: compound 4; then compound 3; then compound 1. At a limit, above all of these: compound 2.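

Exchanging one small chain for another on this carbonyl carbon matters in this assay: 2-chloroethyl in place of dichloromethyl gives a 9.5-fold lower number from compound 3 to compound 4 (0.98 log units; beyond the scatter) although both groups have the same heavy-atom count and no ring. The 2-chloroethyl group also improves on the 2,6-dichlorophenyl group, with a 30-fold lower number from compound 1 to compound 4 (1.48 log units; beyond the scatter) in this comparison. Compound 2 stands at a limit of the assay and not at a number, so its step is an at least 140-fold lower number from compound 2 to compound 4 (2.15 log units; beyond the scatter) as a bound only.

Going by these compounds, whether a longer chain or a terminal amine in place of the chlorine would keep this gain remains open. Nothing shown explains the gain.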